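The source may hold more compounds than are shown below. What is called first, only, known or untested is meant among the compounds shown, and "the series" means these compounds.

Series notes. Compound 3 `CCc1nnn(Cc2ccc(C(F)(F)F)cc2)c1C(=O)N[C@@H](C)c1ccc(C(=O)O)cc1` stands on a limit: in a functional assay on CHO cells for antagonist activity at prostaglandin E2 receptor EP4 subtype (Homo sapiens), read by calcium flux, with a stated time of 15 min (on this read-out higher numbers stand for weaker inhibition and lower numbers for stronger inhibition), compound 3 gives > 10000 nM, which is a limit of the assay and not a number. Compound 2 `Cc1nnn(Cc2ccc(C(F)(F)F)cc2)c1C(=O)N[C@@H](C)c1ccc(C(=O)O)cc1` sits on the same limit, as in this assay compound 2 gives > 10000 nM. Compound 1 `C[C@H](NC(=O)c1nnn(Cc2cccc(C(F)(F)F)c2)c1C(F)(F)F)c1ccc(C(=O)O)cc1` likewise, since in this assay compound 1 gives > 10000 nM, again a limit. The evidence on the measured steps is summed up by the limit of > 10000 nM in this assay, at which 3 of the 3 values shown sit. Among the compounds with values here, the one step between measured compounds that differ in a single place, a step that the two limits leave unreadable from compound 2 to compound 3, cannot be read because both ends are limits, so its size stays unknown.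

Compound 4 `C[C@H](NC(=O)c1c(C2CCC2)nnn1Cc1ccc(C(F)(F)F)cc1)c1ccc(C(=O)O)cc1` differs from compound 3 by cyclobutyl in place of ethyl on an aromatic carbon. Within the data shown here, no measured step touches this change, and the single measured step gives no readable size to build on. Nothing in the shown numbers points to a gain large enough to bring a value out of the limit. The value expected for compound 4 in this assay is therefore most likely again a limit, estimated at 10000 nM with a range from 3000 nM to 30000 nM. The expected step is a number no higher from compound 3 to compound 4 (the limit leaves the size open), that is, no change beyond the scatter is expected.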

Compound 4, half-maximal inhibitory concentration: 75.3 nM
The estimate for compound 4 lay 130-fold (2.12 log units) above the measured number; the whole stated range lies above it.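

In this assay, the carbon of the five-membered aromatic ring with 3 nitrogen that is next to the ring atom bearing a large group proves able to carry a readable inhibition: with the shared core unchanged, ethyl to cyclobutyl gives an at least 130-fold lower number from compound 3 to compound 4 (2.12 log units; beyond the scatter). Methyl to cyclobutyl at the same place gives an at least 130-fold lower number from compound 2 to compound 4 (2.12 log units; beyond the scatter), so the two open-chain groups shown and the ring-bearing group fall on opposite sides of the limit, and the earlier compounds gave no sign that this place could matter at all. Both steps start from a limit, so they bound the change without fixing its size, and the picture of the series still rests largely on that limit: the limit of > 10000 nM in this assay, at which 3 of the 4 values shown sit.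

Open, on these data alone, is whether the gain follows the ring itself or simply the larger number of carbons, since cyclobutyl differs from ethyl in both; cyclopropyl, isopropyl or cyclopentyl at this place would separate the two. Within the data shown here, also open is how far the gain depends on the rest of compound 4, as the only readable change so far is this one at this place.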